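Adding One More Carbon to the Chain

The compounds below may be only part of what the source reports. "The series", "measured", "known", "first", "only" and "open" are said of these compounds alone.

In a functional assay on A549 cells (Homo sapiens) for inhibition, read by sulforhodamine B assay, with a stated time of 72 h (a lower number here means a stronger inhibitor, a higher number a weaker inhibitor), compound 1 (`COc1cc2c(Nc3cccc(Br)c3)ncnc2cc1OCCCn1ccnc1[N+](=O)[O-]`) gives 7830 nM and compound 2 (`COc1cc2c(Nc3cccc(Br)c3)ncnc2cc1OCCCCCn1ccnc1[N+](=O)[O-]`) gives 8420 nM. These two values lie within the usual scatter of each other, so compound 2 stands level with compound 1.

Compound 3 (`COc1cc2c(Nc3cccc(Br)c3)ncnc2cc1OCCCCCCn1ccnc1[N+](=O)[O-]`) differs from compound 2 in one place: (2-nitro-1H-imidazol-1-yl)methyl in place of 2-nitro-1H-imidazol-1-yl on a saturated chain carbon, five bonds along the chain from an oxygen on an aromatic ring. In words, (2-nitro-1H-imidazol-1-yl)methyl stands in place of 2-nitro-1H-imidazol-1-yl on a saturated chain carbon, five bonds along the chain from an oxygen on an aromatic ring.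

Among the compounds with values here, one measured step bears on this change, since it also lengthens the chain: a 1.1-fold higher number from compound 1 to compound 2 (0.03 log units; within the scatter). With so small a precedent, no shift beyond the scatter is expected in this assay. The expected step is a 1.1-fold higher number from compound 2 to compound 3 (0.03 log units; within the scatter). For compound 3 the estimated value is 9000 nM, within an expected range of 4500 nM to 18000 nM.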

Compound 3, half-maximal inhibitory concentration: 20200 nM
Compound 3: the middle estimate sits 2.2-fold (0.35 log units) below what was measured; the whole stated range lies below it.
By their numbers in this assay, from the lowest: compounds 1 and 2 (each within the scatter of the next); then compound 3.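

In this assay the chain at this position is no longer a change without effect: (2-nitro-1H-imidazol-1-yl)methyl in place of 2-nitro-1H-imidazol-1-yl gives a 2.4-fold higher number from compound 2 to compound 3 (0.38 log units; beyond the scatter), a modest step but the first here beyond the scatter. Measured across the full change, 3-(2-nitro-1H-imidazol-1-yl)propyl in place of 2-nitro-1H-imidazol-1-yl gives a 2.6-fold higher number from compound 1 to compound 3 (0.41 log units; beyond the scatter), which makes compound 3 the weakest inhibitor of the three, even though the step between compound 1 and compound 2 stays within the scatter. Nothing available explains this loss of activity.

Three compounds cannot show whether a longer chain would push the number higher still or leave it level. They also leave open whether an amine in place of the 2-nitro-1H-imidazol-1-yl group would behave the same way on any of these chains.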